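Methylsulfanyl to dimethylamino on the shared core

A few compounds are considered here, and "the series" means these few. Any claim that something is new, unique, unknown or untested is made for them only; others in the source may bear on it.

Compound 2 `CSc1ncnc2c1c(-c1cccs1)cn2[C@@H]1O[C@H](CO)[C@@H](O)[C@H]1O` carries a methylsulfanyl group on an aromatic carbon of the shared core. In a functional assay on HCT-116 cells (Homo sapiens), read by MTT assay, with a stated time of 72 h (a higher number here means a weaker inhibitor, a lower number a stronger inhibitor), compound 2 gives only a limit of the assay, > 20000 nM. Compound 1 `Cc1ncnc2c1c(-c1cccs1)cn2[C@@H]1O[C@H](CO)[C@@H](O)[C@H]1O` carries a methyl group on that aromatic carbon instead. In this assay compound 1 likewise returns a limit rather than a number, > 20000 nM. The step that the two limits leave unreadable from compound 1 to compound 2 is therefore of unreadable size, since both values sit at the limit of > 20000 nM in this assay, at which 2 of the 2 values shown sit. Compound 3 `CN(C)c1ncnc2c1c(-c1cccs1)cn2[C@@H]1O[C@H](CO)[C@@H](O)[C@H]1O` remains to be measured, and it differs from compound 2 as dimethylamino in place of methylsulfanyl on an aromatic carbon. Within the data shown here, no measured step bears directly on this change: the single step available, methylsulfanyl in place of methyl, cannot be read, and neither measured compound has a numeric value in this assay. Nothing in the series points to a gain in potency from the dimethylamino group, so the step that the limit leaves unreadable from compound 2 to compound 3 is expected to be small and compound 3 is expected, most probably, to come back at a limit as well. For compound 3 in this assay the estimated value is 25000 nM, with a range from 8000 nM to 80000 nM.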

Compound 3, half-maximal inhibitory concentration: > 20000 nM
Compound 3: a limit, no number; the forecaster's own chance of this, stated with the estimate: 75%; the middle value lies beyond the limit too.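

In this assay compound 3 gives > 20000 nM, a limit of the assay and not a number. No step among compound 1, compound 2 and compound 3 can be read: the limit of > 20000 nM in this assay, at which 3 of the 3 values shown sit.

The compounds shown leave open whether methyl, methylsulfanyl and dimethylamino on this aromatic carbon of the shared core differ at all in potency.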